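The source may report more compounds than this note shows. Statements on the series, on what has been measured and on what is new or still open speak of the compounds shown alone.

Among the measured compounds shown here, the shared core of this series carries an aryl group on the aromatic carbon next to the ring oxygen, and the three measured members differ only in that aryl group. Compound 1 `CCC1=C(O)c2c(oc(-c3ccc(OC)cc3)cc2=O)C(CC)(CC)C1=O` bears a 4-methoxyphenyl there, and in a functional assay on KBVIN cells (Homo sapiens) for antiproliferative activity, read by sulforhodamine B assay, with a stated time of 3 days (on this read-out higher numbers stand for an effect only at larger amounts of compound and lower numbers for an effect already at smaller amounts), compound 1 gives 0.68 uM, the lowest of the three numbers. Compound 2 `CCC1=C(O)c2c(oc(-c3cccc(OC(F)(F)F)c3)cc2=O)C(CC)(CC)C1=O` gives 9.95 uM in this assay, and compound 3 `CCC1=C(O)c2c(oc(-c3cc(Cl)c(OC)c(OC)c3)cc2=O)C(CC)(CC)C1=O` gives 8.4 uM. Both sit well beyond the scatter from compound 1, so compound 1 is the most potent of the measured set, while compound 2 and compound 3 lie within the scatter of each other.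

Compound 4 `CCC1=C(O)c2c(oc(-c3ccc(O)c(O)c3)cc2=O)C(CC)(CC)C1=O` is the next member to be tested. Relative to compound 1 it carries 3,4-dihydroxyphenyl in place of 4-methoxyphenyl on an aromatic carbon. For the measured compounds named here, no measured pair isolates this change, so the expectation rests on the fact that both departures from the 4-methoxyphenyl seen so far, in compound 2 and compound 3, gave higher numbers. Compound 4 is therefore expected to give a higher number than compound 1 in this assay, with the step from compound 1 to compound 4 estimated at a 4.4-fold higher number from compound 1 to compound 4 (0.64 log units; beyond the scatter), a modest loss rather than a large one. The estimate for compound 4 in this assay is 3 uM, within a range from 0.8 uM to 12 uM.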

Compound 4, concentration for half-maximal effect: 5.41 uM
Compound 4: the middle estimate sits 1.8-fold (0.26 log units) below what was measured; the range from low to high includes it.
By their numbers in this assay, from the lowest: compound 1; then compounds 4, 3 and 2 (each within the scatter of the next).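

In this assay, among the compounds shown here, 3,4-dihydroxyphenyl in place of 4-methoxyphenyl on this aromatic carbon gives an 8.0-fold higher number from compound 1 to compound 4 (0.90 log units; beyond the scatter), and this is the first step that can be read directly. For the compounds shown here, it shows that the low number of compound 1 is not kept when the single methoxy group gives way to two hydroxyl groups, even though the entering and leaving groups have the same count of heavy atoms. With compound 2, compound 3 and compound 4 all printing well above compound 1, none of the four compounds goes against the 4-methoxyphenyl being the best aryl group among those shown, but no measurement at hand says why the change costs activity.

This single step replaces the methoxy group and adds a second oxygen substituent at once, so it cannot say which part of the change carries the loss, and a phenyl with one hydroxyl group alone would separate the two. Nor do the compounds shown say how an unsubstituted phenyl, an aminophenyl or an ethoxyphenyl would behave at this position.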